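A Second Methoxy Group on the Aryl Ketone of Compound 1

This account rests on a few compounds, and the source may have more. Where it says the series, first, only, none or still open, it means among the compounds named here.

Compound 1 `COc1ccc(C(=O)/C=C/c2cc(-c3cc(OC)c(OC)c(OC)c3)n3nc(-c4ccccc4)cc3n2)cc1` is one of two measured members of a small series examined in a functional assay on DU-145 cells (Homo sapiens) for antiproliferative activity, read by MTT assay, with a stated time of 24 h; on this read-out lower numbers stand for stronger inhibition and higher numbers for weaker inhibition. In this assay compound 1 gives 25200 nM, the highest of the two numbers shown. Among the measured compounds shown here, its only neighbour, compound 2 `COc1cc(-c2cc(C(=O)/C=C/c3ccccc3)nc3cc(-c4ccccc4)nn23)cc(OC)c1OC`, gives 16300 nM in this assay; the single recorded step, a 1.5-fold lower number from compound 1 to compound 2 (0.19 log units; within the scatter), exchanges the group on the far side of the enone and stays within the scatter. Compound 3 `COc1ccc(C(=O)/C=C/c2cc(-c3cc(OC)c(OC)c(OC)c3)n3nc(-c4ccccc4)cc3n2)cc1OC` has not been measured in this assay. It differs from compound 1 by methoxy in place of hydrogen on an aromatic carbon. For the measured compounds named here, no measured step touches that ring: the change from compound 1 to compound 2 replaces the whole (4-methoxyphenyl)carbonyl end, so it tells only that the two measured numbers lie close together. With nothing bearing directly on the added methoxy group, the author expects for compound 3 no step beyond the scatter, a 1.3-fold lower number from compound 1 to compound 3 (0.10 log units; within the scatter). For compound 3 the estimated value in this assay is therefore 20000 nM, expected to lie between 7000 nM and 60000 nM.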

Compound 3, half-maximal inhibitory concentration: 29900 nM
Beside the measured number, compound 3's estimate is 1.5-fold (0.17 log units) below it; low and high end bracket the measured number.
By their numbers in this assay, from the lowest: compounds 2, 1 and 3 (each within the scatter of the next).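

Read as a single change, the step to the (3,4-dimethoxyphenyl)carbonyl end in this assay gives a 1.2-fold higher number from compound 1 to compound 3 (0.07 log units; within the scatter), and it is the first reading taken on the aryl ketone ring itself, since the earlier step replaced that whole end at once. It shows that a methoxy group can stand on this aromatic carbon, ortho to a methoxy group and meta to a large group, with compound 1 and compound 3 remaining within the scatter of each other, so at this position and for this group the read-out does not separate the two. Nothing shown offers an account of this result.

Among the compounds shown here, whether the same carbon is equally silent to a different kind of group, such as an amine, a carboxylic acid or a longer chain like butoxy, remains open, since methoxy is the only group seen there. For the compounds shown here, also open is what the methoxy group already present in compound 1 contributes, as no step removes it alone or moves it elsewhere on the ring while leaving the rest of the compound in place.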